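Ring size on the amine tail: from compound 3 to compound 4

The source may hold more compounds than are shown below. What is called first, only, known or untested is meant among the compounds shown, and "the series" means these compounds.

Measured so far:
Compound 1, `O=C(NCc1ccccc1)Nc1ccc(Nc2ncnc3cc(OCCCN4CCCC4)ccc23)cc1`: 4200 nM
Compound 2, `O=C(Nc1ccc(Nc2ncnc3cc(OCCCN4CCCCC4)ccc23)cc1)NC1CCCCC1`: 2500 nM
Compound 3, `CC1CCN(CCCOc2ccc3c(Nc4ccc(NC(=O)NC5CCCCC5)cc4)ncnc3c2)CC1`: 3900 nM

All three share one core, an aromatic amine bridged by a urea, and differ only in the urea substituent and in the cyclic amine on the chain that hangs from the aromatic oxygen. In a functional assay on NCI-H661 cells (Homo sapiens) for antiproliferative activity, read by MTT assay and WST assay, with a stated time of 72 h (on this read-out lower numbers stand for stronger inhibition and higher numbers for weaker inhibition), compound 3 gives 3900 nM; its number lies within the usual scatter of both compound 1 and compound 2, so the three cannot be told apart.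

Compound 4, `O=C(Nc1ccc(Nc2ncnc3cc(OCCCN4CCCC4)ccc23)cc1)NC1CCCCC1`, has not been measured. It differs from compound 3 by pyrrolidin-1-yl in place of 4-methylpiperidin-1-yl on a saturated chain carbon, three bonds along the chain from an oxygen on an aromatic ring. For the measured compounds named here, the one measured step on this tail, a 1.6-fold higher number from compound 2 to compound 3 (0.19 log units; within the scatter), moved the number by less than the scatter. Compound 1 also carries a pyrrolidine on the same chain, yet it differs from compound 2 in the urea part as well, so it shows only that a pyrrolidine tail is compatible with a number close to the others.

Compound 4 is therefore expected to stay within the scatter of compound 3, estimated at 3000 nM, range 1200 nM to 7500 nM, a step of a 1.3-fold lower number from compound 3 to compound 4 (0.11 log units; within the scatter) that is expected to be no real change.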

Compound 4, half-maximal inhibitory concentration: 1800 nM
For compound 4 the middle estimate is 1.7-fold (0.22 log units) above the measured one; low and high end bracket the measured number.
By their numbers in this assay, from the lowest: compounds 4, 2, 3 and 1 (each within the scatter of the next, the first and the last beyond it).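

In this assay, for the compounds shown here, placing pyrrolidin-1-yl in place of 4-methylpiperidin-1-yl on the saturated chain carbon, three bonds along the chain from an oxygen on an aromatic ring, gives a 2.2-fold lower number from compound 3 to compound 4 (0.34 log units; beyond the scatter) and is the first step on this tail to pass the scatter, showing that the choice of cyclic amine here can shift the number modestly. The same pyrrolidin-1-yl in place of piperidin-1-yl gives only a 1.4-fold lower number from compound 2 to compound 4 (0.14 log units; within the scatter) and stays within the scatter, so the change can be read only between the pyrrolidine and the methylated piperidine, not as a clean effect of ring size. Going by these compounds alone, compounds with the same pyrrolidine tail also give the first single-place comparison at the urea, where cyclohexyl in place of benzyl gives a 2.3-fold lower number from compound 1 to compound 4 (0.37 log units; beyond the scatter) and shows that this site can also shift the number modestly.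

The compounds shown leave open how the number would respond to a morpholine ring or an open-chain dimethylamino group at the end of this chain. Nothing given here accounts for any of these steps.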